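Compound 3 to compound 4: bromo in place of methoxy

The compounds below may be only part of what the source reports. "The series", "measured", "known", "first", "only" and "open" are said of these compounds alone.

Values so far in an ADME assay on cells (Hepatocyte, Mus musculus) for cytotoxicity, read by MTT assay, with a stated time of 24 h; on this read-out lower numbers stand for higher toxicity in this test and higher numbers for lower toxicity in this test
compound 1 `Cc1ccc(-c2nn(-c3ccccc3)cc2-c2nc3ccccc3[nH]2)cc1` gives > 300000 nM (a limit of the assay)
compound 2 `COc1ccc(S(=O)(=O)n2c(-c3cn(-c4ccccc4)nc3-c3ccc(F)cc3)nc3ccccc32)cc1` gives 105000 nM
compound 3 `COc1ccc(S(=O)(=O)n2c(-c3cn(-c4ccccc4)nc3-c3ccc(C(F)(F)F)cc3)nc3ccccc32)cc1` gives 87400 nM

Among the measured compounds shown here, compound 3 lies within the scatter of compound 2, and these two are the only actual numbers in the set. The reading for compound 1 is a limit of the assay and not a number (> 300000 nM).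

The change to compound 4 `O=S(=O)(c1ccc(Br)cc1)n1c(-c2cn(-c3ccccc3)nc2-c2ccc(C(F)(F)F)cc2)nc2ccccc21` is bromo in place of methoxy on an aromatic carbon, para to a large group, counted as bromo in place of methoxy on an aromatic carbon and reading as 4-methoxyphenyl to 4-bromophenyl. For the measured compounds named here, no measured step covers this exchange. Going by the values given here, the only measured step is a 1.2-fold lower number from compound 2 to compound 3 (0.08 log units; within the scatter) with trifluoromethyl in place of fluoro on an aromatic carbon. That step leaves the methoxy untouched and stays within the scatter, so it offers only indirect guidance. Starting from compound 3 at 87400 nM in this assay the expectation is therefore a small change. The estimated step is a 1.1-fold lower number from compound 3 to compound 4 (0.04 log units; within the scatter) and thus none beyond the scatter. For compound 4 the expected value is 80000 nM with an estimated range (40000 nM to 170000 nM).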

Compound 4, half-maximal cytotoxic concentration: 167000 nM
For compound 4 the middle estimate is 2.1-fold (0.32 log units) below the measured one; the measured number falls inside the stated range.
By their numbers in this assay, from the lowest: compounds 3, 2 and 4 (each within the scatter of the next). At a limit, above all of these: compound 1.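

The exchange of (4-methoxyphenyl)sulfonyl for (4-bromophenyl)sulfonyl is the first change shown at this position, and in this assay it reads as a 1.9-fold higher number from compound 3 to compound 4 (0.28 log units; within the scatter). Alongside the earlier exchange of trifluoromethyl for fluoro, a 1.2-fold lower number from compound 2 to compound 3 (0.08 log units; within the scatter), two different places on the sulfonylated compounds have now each been changed once, and neither step leaves the scatter, so methoxy is not required at this position for a reading of this order in this assay. Only compound 1 sits at a limit of the assay, while compound 4 gives an actual number, so this step can be read in full: the limit of > 300000 nM in this assay, at which 1 of the 4 values shown sits.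

One exchange at one position does not show whether an amine, a carboxylic acid or a nitrile on the same aromatic carbon would also stay within the scatter of compound 3. From the compounds shown here alone, compound 1 differs from the sulfonylated compounds in more than one place and its reading is a limit, so what the (4-bromophenyl)sulfonyl group alone contributes in this assay remains open.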